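Difluorophenyl in Place of Cyanophenyl at the Cytotoxicity Limit

The compounds below may be only part of what the source reports. "The series", "measured", "known", "first", "only" and "open" are said of these compounds alone.

Measured compounds:
Compound 1, `CCOC(=O)c1cc(-c2cccc(OCc3cccc(C#N)c3)c2)on1`, shows only the assay limit > 128000 nM in an ADME assay on Vero cells (Chlorocebus sabaeus) for cytotoxicity, with a stated time of 72 h; a lower number here means a stronger inhibitor, a higher number a weaker inhibitor.
Compound 2, `CCOC(=O)c1cc(-c2cccc(OCc3ccc(C(F)(F)F)cc3)c2)on1`, shows only the limit > 128000 nM in this assay.
Compound 3, `CCOC(=O)c1cc(-c2cccc(OCc3cccc(C(F)(F)F)c3F)c2)on1`, shows only the limit > 128000 nM in this assay.

Compound 1 stands at the limit of this assay, as do the other two, which the limit of > 128000 nM in this assay, at which 3 of the 3 values shown sit, records. Within the data shown here, no step between measured compounds can be read from these values. Compound 4, `CCOC(=O)c1cc(-c2cccc(OCc3ccc(F)c(F)c3)c2)on1`, differs from compound 1 by 3,4-difluorophenyl in place of 3-cyanophenyl on a saturated chain carbon bound to an oxygen on an aromatic ring. For compound 4 in this assay the expected step is a step that the limit leaves unreadable from compound 1 to compound 4, meaning none beyond the scatter. Compound 4 is therefore estimated at 130000 nM, within 50000 nM to 400000 nM, most likely reported again only as a limit.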

Compound 4, half-maximal inhibitory concentration: > 128000 nM
Compound 4 gave a limit, no number (the forecaster's own chance of this, stated with the estimate: 85%); the middle value is on the limit's open side.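

Among these compounds, compound 1 and compound 4 both give only a limit, not a number, so no step between them can be read: the limit of > 128000 nM in this assay, at which 4 of the 4 values shown sit.

The compounds shown leave open whether compound 1 and compound 4 differ at all in this assay.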